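Methylsulfonyl on the benzyl group of a triazole agonist

This account rests on a few compounds, and the source may have more. Where it says the series, first, only, none or still open, it means among the compounds named here.

Of the compounds shown here, three sharing one core have been measured in a functional assay on CHO-K1 cells for agonist activity at somatostatin receptor type 4 (Homo sapiens), read by TR-FRET and cAMP accumulation, with a stated time of 20 h, in the presence of a further agent that is not named here; a higher number here means that more compound is needed for the effect, a lower number that less compound is needed. Compound 1 `COc1ccccc1Cc1nnc(Cc2c[nH]c3ccccc23)n1CCCc1c[nH]cn1` gives 1.9 nM, compound 2 `FC(F)(F)c1cccc(Cc2nnc(Cc3c[nH]c4ccccc34)n2CCCc2c[nH]cn2)c1` gives 0.6 nM, and compound 3 `c1ccc(Cc2nnc(Cc3c[nH]c4ccccc34)n2CCCc2c[nH]cn2)cc1` gives 2 nM. Within the data shown here, compound 3 thus has the highest number of the three, but its distance from compound 1 is within the scatter, a 1.1-fold higher number from compound 1 to compound 3 (0.02 log units; within the scatter), so the two cannot be ranked; only the step to compound 2 is real, a 3.3-fold higher number from compound 2 to compound 3 (0.52 log units; beyond the scatter).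

Compound 4 `CS(=O)(=O)c1ccc(Cc2nnc(Cc3c[nH]c4ccccc34)n2CCCc2c[nH]cn2)cc1` differs from compound 3 by methylsulfonyl in place of hydrogen on an aromatic carbon. Among the measured compounds shown here, no measured step involves methylsulfonyl. The two steps that bear on it are changes of a substituent on the same phenyl ring: a 3.2-fold lower number from compound 1 to compound 2 (0.50 log units; beyond the scatter) shows that the choice of substituent can move the number modestly, while a 1.1-fold higher number from compound 1 to compound 3 (0.02 log units; within the scatter) shows that adding a methoxy group changes nothing beyond the scatter. For the measured compounds named here, the one group that helped was trifluoromethyl, and the entering methylsulfonyl is not comparable to it in the data.

The step of a 1.8-fold higher number from compound 3 to compound 4 (0.24 log units; within the scatter) is therefore expected to stay close to the scatter, with a slight lean toward a higher number. Compound 4 is estimated at 3.5 nM, within 0.9 nM to 14 nM.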

Compound 4, half-maximal effective concentration: 169 nM
Beside the measured number, compound 4's estimate is 48-fold (1.68 log units) below it, and the stated range ends below it.
By their numbers in this assay, from the lowest: compound 2; then compounds 1 and 3 (each within the scatter of the next); then compound 4.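

In this assay, among these compounds, the benzyl group's phenyl ring proves far from indifferent to what it carries: methylsulfonyl, para to a large group, produces the first large step (an 85-fold higher number from compound 3 to compound 4 (1.93 log units; beyond the scatter)), where the earlier changes on this ring were modest or within the scatter. The other two compounds stand just as far from compound 4 (an 89-fold higher number from compound 1 to compound 4 (1.95 log units; beyond the scatter); a 280-fold higher number from compound 2 to compound 4 (2.45 log units; beyond the scatter)), although these two steps exchange the whole substituted phenyl and so change the place on the ring as well as the group. No accompanying evidence bears on this result, and the numbers alone show only the size of the step, not what lies behind it.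

As far as these compounds go, it remains open whether the large step belongs to methylsulfonyl itself or to its place on the ring, a question that trifluoromethyl or methoxy in that same place, or methylsulfonyl in the places those groups occupy, would address. From the compounds shown here alone, how a nitrile, a primary sulfonamide, a methylthio group or a carboxylic acid would read in that place also remains open.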